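A few compounds are considered here, and "the series" means these few. Any claim that something is new, unique, unknown or untested is made for them only; others in the source may bear on it.

Measured in an ADME assay on brain (Rattus norvegicus) for protein binding; on this read-out lower numbers stand for a smaller free fraction and higher numbers for a larger free fraction:
Compound 1 `O=C1O[C@]2(CC[C@H](CNc3ccc(-c4ncccc4F)cn3)CC2)CN1c1cccnn1`: 0.052
Compound 2 `O=C1O[C@]2(CC[C@H](CNc3cnn(-c4ccccc4F)c3)CC2)CN1c1cccnn1`: 0.031

Compound 2, at 0.031, cannot be told apart from compound 1, since the two values lie within the usual scatter of each other. Compound 3 `O=C1O[C@]2(CC[C@H](CNc3cnn(-c4ccccc4F)c3)CC2)CN1c1cccnc1F` keeps the rest of compound 2 but carries 2-fluoropyridin-3-yl in place of pyridazin-3-yl on an amide-type nitrogen in a ring. Among the measured compounds shown here, no measured pair shows this change, so the expectation is loose: a modest step toward a smaller free fraction, possibly no larger than the scatter. The expected step is a 1.6-fold lower number from compound 2 to compound 3 (0.19 log units; within the scatter). Compound 3 is estimated at 0.02, with an expected range from 0.01 to 0.04.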

Compound 3, unbound fraction: 0.019
For compound 3 the middle estimate is 1.1-fold (0.02 log units) above the measured one, within the range that was stated.
By their numbers in this assay, from the lowest: compounds 3, 2 and 1 (each within the scatter of the next, the first and the last beyond it).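

Exchanging pyridazin-3-yl for 2-fluoropyridin-3-yl on the amide-type nitrogen gives, in this assay, a 1.6-fold lower number from compound 2 to compound 3 (0.21 log units; within the scatter). Among the compounds shown here, this is the first reading at this position, and it shows that one ring nitrogen can give way to a ring carbon and a fluorine appear without a shift that can be told from the scatter. Nothing measured here explains the result.

Going by these compounds, whether a carboxylic acid or an amine on this ring would shift the free fraction beyond the scatter stays open. So does whether the same exchange would read alike on the core of compound 1.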